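Methyl in Place of Methoxy on Compound 2

The source may hold more compounds than are shown below. What is called first, only, known or untested is meant among the compounds shown, and "the series" means these compounds.

Among the measured compounds shown here, in an assay on brain for displacement of a labelled ligand from 5-hydroxytryptamine receptor 4 (Cavia porcellus), with a stated time of 30 min, in the presence of a further agent that is not named here (a lower number here means a stronger inhibitor, a higher number a weaker inhibitor), compound 2 `COc1ccc(S(=O)(=O)NCCN2CCC(CCC(=O)c3cc(Cl)c(N)cc3OC)CC2)cc1` gives 12.3 nM, and its only neighbour, compound 1 `COc1ccc(S(=O)(=O)NCCN2CCC(CCC(=O)c3cc(Cl)c(N)cc3OC)CC2)cc1Br`, gives 24.3 nM; the step of a 2.0-fold lower number from compound 1 to compound 2 (0.30 log units; within the scatter) lies within the scatter. Compound 3 `COc1cc(N)c(Cl)cc1C(=O)CCC1CCN(CCNS(=O)(=O)c2ccc(C)cc2)CC1` differs from compound 2 by methyl in place of methoxy on an aromatic carbon. For the measured compounds named here, no measured step touches this position, and the single known step, hydrogen in place of bromo on an aromatic carbon, was itself within the scatter. A step of a 1.6-fold higher number from compound 2 to compound 3 (0.21 log units; within the scatter) is therefore expected, without clear movement beyond the scatter. Compound 3 is estimated at 20 nM, in the range 7 nM to 55 nM.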

Compound 3, inhibition constant: 18 nM
Beside the measured number, compound 3's estimate is 1.1-fold (0.05 log units) above it; the range from low to high includes it.
By their numbers in this assay, from the lowest: compounds 2, 3 and 1 (each within the scatter of the next).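

In this assay the position para to the large group now has a measured step of its own: methyl in place of methoxy gives a 1.5-fold higher number from compound 2 to compound 3 (0.17 log units; within the scatter), so 4-methoxyphenyl and 4-methylphenyl cannot be told apart here. With 4-methylphenyl in place of 3-bromo-4-methoxyphenyl, the reading is a 1.4-fold lower number from compound 1 to compound 3 (0.13 log units; within the scatter), so even both replacements together do not separate compound 1 from compound 3. No evidence at hand bears on this result. Going by these compounds, whether an amine, a carboxylic acid or a longer chain at this position would stand beyond the scatter remains open.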